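Swapping Chloro for Bromo: an Expected Small Change

The compounds below may be only part of what the source reports. "The series", "measured", "known", "first", "only" and "open" are said of these compounds alone.

Compound 1 `O=C1Nc2ccc(Br)cc2/C1=N/NC(=S)Nc1ccc(Cl)cc1` gives 88000 nM in a functional assay on L1210 cells (Mus musculus), with a stated time of 48 h; on this read-out lower numbers stand for stronger inhibition and higher numbers for weaker inhibition.
Compound 2 `O=C1/C(=N\NC(=S)Nc2ccc(Cl)cc2)c2cc(F)ccc2N1Cc1ccc(F)cc1` gives 154000 nM in this assay.
Compound 3 `O=C1/C(=N\NC(=S)Nc2ccc(Cl)cc2)c2cc(Cl)ccc2N1Cc1ccc(F)cc1` gives 103000 nM in this assay.

Among these three numbers compound 3 stands second highest, but its value lies within the scatter of both compound 1 and compound 2, so none of the three can be ranked against the others. For the measured compounds named here, the one measured step that bears on the change in question is a 1.5-fold lower number from compound 2 to compound 3 (0.17 log units; within the scatter). Compound 4 `O=C1/C(=N\NC(=S)Nc2ccc(Cl)cc2)c2cc(Br)ccc2N1Cc1ccc(F)cc1` is made from compound 3 by the change (bromo in place of chloro on an aromatic carbon), a further swap of one halogen for another at the same aromatic carbon. That earlier halogen swap stayed within the scatter. The step of a 1.0-fold lower number from compound 3 to compound 4 (0.01 log units; within the scatter) is therefore expected to stay within the scatter as well, with no direction favoured. Compound 4 is estimated to give 100000 nM, expected to fall between 45000 nM and 220000 nM in this assay.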

Compound 4, half-maximal inhibitory concentration: 196000 nM
For compound 4 the middle estimate is 2.0-fold (0.29 log units) below the measured one; low and high end bracket the measured number.
By their numbers in this assay, from the lowest: compounds 1, 3, 2 and 4 (each within the scatter of the next, the first and the last beyond it).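

At this aromatic carbon, bromo in place of chloro (a 1.9-fold higher number from compound 3 to compound 4 (0.28 log units; within the scatter)) and bromo in place of fluoro (a 1.3-fold higher number from compound 2 to compound 4 (0.10 log units; within the scatter)) both stay within the scatter, so the three halogens cannot be told apart in this assay. For the compounds shown here, the one step beyond the scatter, and a modest one, is at a different place: 4-fluorobenzyl in place of hydrogen on an amide-type nitrogen in a ring (a 2.2-fold higher number from compound 1 to compound 4 (0.35 log units; beyond the scatter)). Nothing available gives a reason for either result.

On these data alone, it remains open whether a non-halogen group at this carbon, such as an amine or a methoxy, would move the number beyond the scatter. The nitrogen step is also shown only with bromo on the ring, so its size with chloro or fluoro there is unknown.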